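The source may hold more compounds than are shown below. What is called first, only, known or untested is meant among the compounds shown, and "the series" means these compounds.

In an in vitro ADME assay on the whole organism (small intestine) for pharmacokinetics, with Rattus norvegicus as the target (a lower number here means that the compound disappears faster, a higher number that the compound lasts longer), compound 1 (`CCOC(=O)CN(Cc1ccccc1)C(=O)/C(C)=C/c1ccc(C(=O)Oc2ccc(C(=N)N)cc2)cc1`) gives 0.733 h and compound 2 (`C/C(=C\c1ccc(C(=O)Oc2ccc(C(=N)N)cc2)cc1)C(=O)N(CC(=O)O)Cc1ccccc1`) gives 0.833 h, so the two values lie within the scatter of each other. Compound 3 (`CCOC(=O)CN(C(=O)/C(C)=C/c1ccc(C(=O)Oc2ccc(C(=N)N)cc2)cc1)C1CCCCC1`) keeps the core of compound 1 but carries cyclohexyl in place of benzyl on an amide-type nitrogen. Among the compounds with values here, the one measured step, a 1.1-fold higher number from compound 1 to compound 2 (0.06 log units; within the scatter), exchanges ethyl for hydrogen at a different place in the molecule. It shows how little that exchange moved the number, but it says nothing direct about the group on the nitrogen. Within the data shown here, no measured step touches benzyl, so the evidence for this change is thin. No step beyond the scatter is therefore expected in this assay, in either direction. The expected step is a 1.0-fold lower number from compound 1 to compound 3 (0.02 log units; within the scatter). Compound 3 is estimated at 0.7 h, with an expected range from 0.38 h to 1.3 h.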

Compound 3, half-life: > 1 h
Compound 3 was reported as a limit (the forecaster's own chance of this, stated with the estimate: 3%); middle value at least 1.4-fold (0.15 log units) from the limit.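

In this assay, cyclohexyl in place of benzyl on an amide-type nitrogen gives an at least 1.3-fold higher number from compound 1 to compound 3 (0.13 log units; that floor lies within the scatter), the first measured step at this position, where compound 2 had shown only a change elsewhere in the molecule. The floor of this step lies within the scatter, so the exchange of the aromatic ring for a non-aromatic one does not lower the number, but it is not shown to raise it beyond the scatter. The value of compound 3 is a limit and not a number: the limit of > 1 h in this assay, at which 1 of the 3 values shown sits.

The compounds shown leave open how large the step from benzyl to cyclohexyl really is. They also leave open what a longer chain or an amine on this nitrogen would do, and whether a carboxylic acid in place of the ethyl ester would behave the same with cyclohexyl on the nitrogen.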